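A few compounds are considered here, and "the series" means these few. Any claim that something is new, unique, unknown or untested is made for them only; others in the source may bear on it.

Working notes on the aryl urea series. Compound 1 `CC(C)c1ccc(NC(=O)N[C@@H](C)c2ccccc2)cc1` gives 86% in an ADME assay on the whole organism with Oryza sativa as the target, tested at 10 uM; a lower number here means a stronger effect, a higher number a weaker effect of the compound at the concentration tested; compound 2 `CCCCc1ccc(NC(=O)N[C@@H](C)c2ccccc2)cc1` gives 60%; compound 3 `CCCCCc1ccc(NC(=O)N[C@H](C)c2ccccc2)cc1` gives 97%. Compound 3 stands highest of the three numbers, beyond the scatter from compound 1 and further still from compound 2. For the measured compounds named here, the only measured step, a number 26 percentage points lower from compound 1 to compound 2 (beyond the scatter), alters the alkyl group on the aromatic carbon and says nothing about configuration. Compound 4 `CCCCCc1ccc(NC(=O)N[C@@H](C)c2ccccc2)cc1`, not yet measured, differs from compound 3 by the two compounds have the same atoms and bonds and differ only in configuration as drawn: 1 of 1 stereo elements differ; a stereocentre at a saturated chain carbon is drawn R in compound 3 and S in compound 4. Going by the values given here, no measured pair changes configuration alone, so the size of this step cannot be read from the data. In this assay compound 4 is estimated at 85%, range 55% to 100%. The step of a number 12 percentage points lower from compound 3 to compound 4 (beyond the scatter) is expected to be small, leaning lower because compound 3 already gives 97%.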

Compound 4, a percentage reported as activity, at one concentration (the size of the read-out at that concentration, not a potency): 93%
Compound 4: middle estimate off by 8 percentage points, on the low side; low and high end bracket the measured number.
By their numbers in this assay, from the lowest: compound 2; then compounds 1, 4 and 3 (each within the scatter of the next, the first and the last beyond it).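

In this assay, the change at the stereocentre on the saturated chain carbon gives a number 4 percentage points lower from compound 3 to compound 4 (within the scatter), so with pentyl on the aromatic carbon, configuration at this position shows no effect beyond the scatter: the fact that compounds 3 and 4 differ only in the configuration as drawn. With configuration held as drawn, the butyl result does not carry over to the longer chain: methyl in place of hydrogen on a saturated chain carbon, four bonds along the chain from an aromatic carbon, gives a number 33 percentage points higher from compound 2 to compound 4 (beyond the scatter). Exchanging the alkyl group on the aromatic carbon gives a number 7 percentage points higher from compound 1 to compound 4 (within the scatter).

On these data alone, whether configuration matters equally with butyl on the aromatic carbon stays open, as does the outcome with a hexyl chain or a carboxylic acid there.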